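This account rests on a few compounds, and the source may have more. Where it says the series, first, only, none or still open, it means among the compounds named here.

Compound 1 `CN(C)c1ccc(/C=C/C(=O)/C(CNc2ccccc2)=C(O)/C=C/c2ccc(N(C)C)cc2)cc1`: 52.1 ug/mL
Compound 2 `COc1ccccc1NC/C(C(=O)/C=C/c1ccc(N(C)C)cc1)=C(O)\C=C\c1ccc(N(C)C)cc1`: 53.9 ug/mL
Compound 3 `COc1ccc(-n2nc(/C=C/c3ccc(N(C)C)cc3)cc2/C=C/c2ccc(N(C)C)cc2)cc1`: 79.6 ug/mL

All three compounds were measured in a physicochemical assay; a lower number here means a stronger inhibitor, a higher number a weaker inhibitor. Compound 3 gives 79.6 ug/mL, and its gaps to compound 1 and to compound 2 both lie within the usual scatter of repeated measurements, so the three numbers cannot be put in a firm order.

Compound 4 `CN(C)c1ccc(/C=C/c2cc(/C=C/c3ccc(N(C)C)cc3)n(-c3ccc(F)cc3)n2)cc1` keeps the core of compound 3 and differs at one place: fluoro in place of methoxy on an aromatic carbon. In words, this is fluoro in place of methoxy on an aromatic carbon, or 4-methoxyphenyl to 4-fluorophenyl.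

For the measured compounds named here, only one measured step offers any guidance. Going from compound 1 to compound 2 puts methoxy in place of hydrogen on an aromatic carbon, and the result is a 1.0-fold higher number from compound 1 to compound 2 (0.01 log units; within the scatter). That step involves a methoxy group, but it sits on the core of compound 1 rather than that of compound 3, so it is a loose guide. Going by the values given here, no measured compound here carries fluoro, which leaves the direction open. No step beyond the scatter is therefore expected, and the estimated change is a 1.1-fold lower number from compound 3 to compound 4 (0.06 log units; within the scatter). For compound 4 the expected value is 70 ug/mL, with an estimated range of 35 ug/mL to 130 ug/mL.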

Compound 4, half-maximal inhibitory concentration: 89.1 ug/mL
For compound 4 the middle estimate is 1.3-fold (0.10 log units) below the measured one; the measured number falls inside the stated range.
By their numbers in this assay, from the lowest: compounds 1, 2, 3 and 4 (each within the scatter of the next).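

On the core of compound 3, the change from 4-methoxyphenyl to 4-fluorophenyl gives a 1.1-fold higher number from compound 3 to compound 4 (0.05 log units; within the scatter) in this assay, so the two compounds cannot be told apart. The earlier compounds shown here showed methoxy only against hydrogen, and on a different core; this pair adds a second kind of group and a different site, an aromatic carbon para to a large group, where two heavy atoms and one hydrogen-bond acceptor leave, one heavy atom enters, and the reading still does not separate. No other measurement here bears on why this exchange leaves the reading within the scatter.

For the compounds shown here, with methoxy and fluoro as the only groups compared at this position, it remains open whether an amine, a carboxylic acid or a longer chain such as butoxy would move the number beyond the scatter. On these data alone, it also remains open whether fluoro in place of methoxy would read the same way on the aromatic ring of compound 2, where the core is different and the methoxy sits elsewhere.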